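The source may hold more compounds than are shown below. What is called first, only, known or untested is meant among the compounds shown, and "the series" means these compounds.

Measured compounds:
compound 1, `CC(=O)Nc1ccc(S(=O)(=O)NNC(=O)c2cccnc2Nc2ccc(Cl)cc2)cc1` — > 100000 nM
compound 2, `O=C(NNS(=O)(=O)c1ccc(F)cc1)c1cccnc1Nc1ccc(Cl)cc1Cl` — > 100000 nM

The two compounds were tested in a functional assay on SNB-75 cells (Homo sapiens) for antiproliferative activity; on this read-out higher numbers stand for weaker inhibition of growth and lower numbers for stronger inhibition of growth. Compound 1 gives > 100000 nM, which is a limit of the assay and not a number. Compound 2 likewise gives > 100000 nM, again a limit. Both values therefore sit at the limit of > 100000 nM in this assay, at which 2 of the 2 values shown sit, and neither compound shows measurable growth inhibition within the tested range.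

The untested compound 3, `O=C(NNS(=O)(=O)c1ccc(Cl)cc1Cl)c1cccnc1Nc1ccc(Cl)cc1`, is built from compound 1 by one change: 2,4-dichlorophenyl in place of 4-acetamidophenyl on a sulfonyl sulfur. For the measured compounds named here, no measured step accompanies this change, so its effect can only be guessed. Because compound 1 already sits at the limit of > 100000 nM in this assay, at which 2 of the 2 values shown sit, the step of a number no higher from compound 1 to compound 3 (the limit leaves the size open) is expected to be none beyond the scatter, with compound 3 most likely also returning only a limit. Compound 3 is expected to give 100000 nM, within a range from 30000 nM to 300000 nM.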

Compound 3, concentration for total growth inhibition: 85100 nM
Beside the measured number, compound 3's estimate is 1.2-fold (0.07 log units) above it; measured number inside the range.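

In this assay, for the compounds shown here, compound 3 gives 85100 nM, the only value among the three compounds that is not a limit, so a sulfonyl sulfur carrying 2,4-dichlorophenyl still allows a reading inside the tested range. Compound 1, with 4-acetamidophenyl in that place, gives > 100000 nM, which is a limit. The change reads as an at least 1.1-fold lower number from compound 1 to compound 3 (0.07 log units; that floor lies within the scatter), so this result alone does not establish a real gain from the swap, and the other two values stay at the ceiling: the limit of > 100000 nM in this assay, at which 2 of the 3 values shown sit.

As far as these compounds go, the true size of the step remains open, since only its floor can be read. Also open, from the compounds shown here alone, is whether a plain phenyl, a 4-chlorophenyl or a 4-methoxyphenyl on the sulfonyl sulfur would give a number in this assay or return to the limit.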